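Swapping the chloromethyl for a short alkenyl chain

This account rests on a few compounds, and the source may have more. Where it says the series, first, only, none or still open, it means among the compounds named here.

The shared core carries an amide on an aromatic ring; what sits on that amide's carbonyl carbon is where the compounds differ. Compound 1 is `O=C(CCl)Nc1ccc(Cn2nc(-c3ccc(Oc4ccccc4)cc3)cc2CO)cc1`, and in a functional assay on JeKo-1 cells (Homo sapiens) for inhibition, read by luminescence and CellTiter-Glo, with a stated time of 72 h (a lower number here means a stronger inhibitor, a higher number a weaker inhibitor), compound 1 gives 400 nM, the lowest of the two numbers available. Compound 2, `C=CC(=O)Nc1ccc(Cn2nc(-c3ccc(Oc4ccccc4)cc3)cc2C(=O)OCC)cc1`, is built differently in two places, and in this assay compound 2 gives 10900 nM, a number far beyond the scatter from that of compound 1; with two changes at once, the two values alone cannot say which change is responsible.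

Compound 3, `C/C=C/C(=O)Nc1ccc(Cn2nc(-c3ccc(Oc4ccccc4)cc3)cc2CO)cc1`, is not yet measured. It differs from compound 1 in a single place: prop-1-en-1-yl in place of chloromethyl on a carbonyl carbon. Among the measured compounds shown here, there is no measured pair that shows exactly this change, so the expectation rests on the two values at hand. Given that compound 2 reads 10900 nM, the step from compound 1 to compound 3 is expected to be upward, toward a weaker inhibitor, at a 7.5-fold higher number from compound 1 to compound 3 (0.88 log units; beyond the scatter). Compound 3 is therefore estimated at 3000 nM, within a range from 800 nM to 12000 nM.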

Compound 3, half-maximal inhibitory concentration: > 60000 nM
Compound 3 gave a limit, no number (the forecaster's own chance of this, stated with the estimate: 5%); middle value at least 20-fold (1.30 log units) from the limit.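

Compound 1 and compound 2 differ in two places, so their values could not tie a change in activity to either one, but compound 1 and compound 3 differ only in the group on a carbonyl carbon whose other neighbour is an amide-type nitrogen: in this assay, replacing chloromethyl with prop-1-en-1-yl gives an at least 150-fold higher number from compound 1 to compound 3 (2.17 log units; beyond the scatter). This shows that, with the rest of compound 1 unchanged, this single position can decide whether the compound has measurable inhibition within the range of the assay. For compound 3, > 60000 nM is a limit of the assay and not a number, so the step gives a minimum size and not an exact one: the limit of > 60000 nM in this assay, at which 1 of the 3 values shown sits.

The compounds shown do not separate the effect of the other place where compound 2 differs from compound 1, and they give only one direct comparison at this carbonyl carbon. A plain methyl, a bromomethyl or a longer chain carrying an amine at this position would show how much of the step is specific to chloromethyl and how much to prop-1-en-1-yl.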